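A Smaller Saturated Amine on the Side Chain of Compound 3

This account rests on a few compounds, and the source may have more. Where it says the series, first, only, none or still open, it means among the compounds named here.

Three compounds share one core and differ only in the group on a saturated chain carbon bound to a saturated ring carbon. Compound 1 `COc1ccc2[nH]c(C(=O)N3CC(=O)N(Cc4ccccc4)[C@@H](CN4CCC(OC)CC4)C3)cc2c1` carries a 4-methoxypiperidin-1-yl group, compound 2 `COc1ccc2[nH]c(C(=O)N3CC(=O)N(Cc4ccccc4)[C@@H](Cc4ccccn4)C3)cc2c1` a pyridin-2-yl group, and compound 3 `COc1ccc2[nH]c(C(=O)N3CC(=O)N(Cc4ccccc4)[C@@H](CN4[C@H](C)COC[C@@H]4C)C3)cc2c1` a 3,5-dimethylmorpholin-4-yl group. In a physicochemical assay for solubility, read by spectrophotometry, in phosphate buffer, with a stated time of 2 h, at pH 7.4 (a lower number here means a less soluble compound, a higher number a more soluble compound), compound 1 reaches a limit of the measurement, > 25000 nM. Compound 2 also reaches a limit in this assay, > 100000 nM. Compound 3 likewise sits at a limit in this assay, > 100000 nM. The values fall at the limit of > 100000 nM in this assay, at which 2 of the 3 values shown sit, or at the limit of > 25000 nM in this assay, at which 1 of the 3 values shown sits, so none of the steps a step that the two limits leave unreadable from compound 1 to compound 2, a step that the two limits leave unreadable from compound 1 to compound 3 or a step that the two limits leave unreadable from compound 2 to compound 3 has a readable size.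

Compound 4 `COc1ccc2[nH]c(C(=O)N3CC(=O)N(Cc4ccccc4)[C@@H](CN4CC5CC5C4)C3)cc2c1` differs from compound 3 by a group of 6 heavy atoms (5 carbon, 1 nitrogen; one three-membered non-aromatic ring of carbon only, one five-membered non-aromatic ring with 1 hetero atom) in place of a group of 8 heavy atoms (6 carbon, 1 nitrogen, 1 oxygen; one six-membered non-aromatic ring with 2 hetero atoms), on a saturated chain carbon bound to a saturated ring carbon. Going by the values given here, no measured step gives a size for this change; the neighbours only show that every variant so far reaches a limit. Compound 4 is therefore expected at 100000 nM, in a range from 30000 nM to 300000 nM. The expected step is a number no higher from compound 3 to compound 4 (the limit leaves the size open), no change beyond the scatter.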

Compound 4, solubility: 17500 nM
The estimate for compound 4 lay 5.7-fold (0.76 log units) above the measured number; the measured number lies below the stated range.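

Going by these compounds alone, compound 4 is the first compound here whose number in this assay is not a limit, which shows that the number can fall below the limits when only the group on a saturated chain carbon bound to a saturated ring carbon changes. The group with a three-membered and a five-membered non-aromatic ring gives an at least 5.7-fold lower number from compound 3 to compound 4 (0.75 log units; beyond the scatter), and it gives an at least 5.7-fold lower number from compound 2 to compound 4 (0.75 log units; beyond the scatter). Against the 4-methoxypiperidin-1-yl group, the comparison is less firm: an at least 1.4-fold lower number from compound 1 to compound 4 (0.15 log units; that floor lies within the scatter).

As far as these compounds go, the steps among compound 1, compound 2 and compound 3 cannot be read, and the full size of each step to compound 4 stays open, since the other values are limits: the limit of > 100000 nM in this assay, at which 2 of the 4 values shown sit; (the limit of > 25000 nM in this assay, at which 1 of the 4 values shown sits). From the compounds shown here alone, whether a dimethylamino group or an unsubstituted piperidin-1-yl group in this place would give a number or a limit also remains open.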